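The source may report more compounds than this note shows. Statements on the series, on what has been measured and on what is new or still open speak of the compounds shown alone.

In an ADME assay (liver) for metabolic stability, with Liver microsome (Rattus norvegicus) as the target, using microsomes and NADPH, with a stated time of 30 min (a higher number here means faster removal of the compound, a lower number slower removal), the measured compounds give:

- compound 1 `CC#C[C@H]1CN(S(=O)(=O)c2ccc(N)nc2)CCN1c1ccc(S(=O)(=NC)C(F)(F)F)cc1`: 257 mL.min-1.g-1
- compound 2 `C#CCC(O)(c1ccc(N2CCN(S(=O)(=O)c3ccc(N)nc3)C[C@@H]2C#CC)cc1)C(F)(F)F`: 59 mL.min-1.g-1
- compound 3 `CC#C[C@H]1CN(S(=O)(=O)c2ccc(N)nc2)CCN1c1ccc(C(O)(COC)C(F)(F)F)cc1`: 93 mL.min-1.g-1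

Compound 3 stands second highest of these three numbers. Compound 4 `CC#CCC(O)(c1ccc(N2CCN(S(=O)(=O)c3ccc(N)nc3)C[C@@H]2C#CC)cc1)C(F)(F)F` has not yet been measured. It differs from compound 3 as follows: prop-1-yn-1-yl in place of methoxy on a saturated chain carbon, two bonds along the chain from an aromatic carbon and an oxygen on a saturated carbon. The nearest guide is a 1.6-fold higher number from compound 2 to compound 3 (0.20 log units; within the scatter), with methoxy in place of ethynyl at this same place, and that step stays within the scatter. The larger steps, a 4.4-fold lower number from compound 1 to compound 2 (0.64 log units; beyond the scatter) and a 2.8-fold lower number from compound 1 to compound 3 (0.44 log units; beyond the scatter), involve a change on an aromatic carbon instead, so they bear less directly here. With so small a step as the guide, no change beyond the scatter is expected, and the expected step is a 1.1-fold lower number from compound 3 to compound 4 (0.04 log units; within the scatter). For compound 4 the estimated value is 85 mL.min-1.g-1, with an expected range from 40 mL.min-1.g-1 to 180 mL.min-1.g-1.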

Compound 4, intrinsic clearance in microsomes: 115 mL.min-1.g-1
For compound 4 the middle estimate is 1.4-fold (0.13 log units) below the measured one; low and high end bracket the measured number.
By their numbers in this assay, from the lowest: compounds 2, 3 and 4 (each within the scatter of the next); then compound 1.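

In this assay, the step of a 1.2-fold higher number from compound 3 to compound 4 (0.09 log units; within the scatter) for prop-1-yn-1-yl in place of methoxy and the step of a 1.9-fold higher number from compound 2 to compound 4 (0.29 log units; within the scatter) for methyl in place of hydrogen on the triple-bonded carbon both stay within the scatter, so this place has now accepted a third group without a clear shift. Only the change on the aromatic carbon, a 2.2-fold lower number from compound 1 to compound 4 (0.35 log units; beyond the scatter) here, goes beyond the scatter. No measured evidence accounts for these numbers. On these data alone, whether an amine, a carboxylic acid or a longer chain at this place would shift the number beyond the scatter remains open.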